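Aryl swap on the amino group: compound 3 to compound 4

The compounds below may be only part of what the source reports. "The series", "measured", "known", "first", "only" and "open" are said of these compounds alone.

In a functional assay on HL-60 cells (Homo sapiens) for antiproliferative activity, read by CCK-8 assay, with a stated time of 72 h (a lower number here means a stronger inhibitor, a higher number a weaker inhibitor), compound 1 (`COc1cccc(Nc2nc(Nc3cc(C)[nH]n3)cc(N3CCN(C)CC3)n2)c1`) gives 397 nM while compound 2 (`Cc1cc(Nc2cc(N3CCN(C)CC3)nc(Nc3cccc([N+](=O)[O-])c3)n2)n[nH]1`) gives 90.9 nM and compound 3 (`Cc1cc(Nc2cc(N3CCN(C)CC3)nc(Nc3cccc(Cl)c3)n2)n[nH]1`) gives 131 nM on the same read-out. Nitro in place of methoxy gives a 4.4-fold lower number from compound 1 to compound 2 (0.64 log units; beyond the scatter) and chloro in place of methoxy gives a 3.0-fold lower number from compound 1 to compound 3 (0.48 log units; beyond the scatter) as modest steps beyond the scatter. Chloro in place of nitro gives a 1.4-fold higher number from compound 2 to compound 3 (0.16 log units; within the scatter) within the scatter. Compound 3 therefore sits level with compound 2 and clear of the higher number of compound 1.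

Compound 4 (`Cc1cc(Nc2cc(N3CCN(C)CC3)nc(Nc3ccc(C#N)cc3)n2)n[nH]1`) carries 4-cyanophenyl in place of 3-chlorophenyl on a nitrogen on an aromatic ring. Among the compounds with values here, all three measured steps change a group on this same ring, but no measured compound carries a nitrile, so the guide is indirect. No methoxy leaves here, so the closest guide is a 1.4-fold higher number from compound 2 to compound 3 (0.16 log units; within the scatter) and not the two steps away from methoxy. No step beyond the scatter is expected in this assay in either direction. The estimated step is a 1.1-fold lower number from compound 3 to compound 4 (0.04 log units; within the scatter) and remains an expectation only. Compound 4 is expected at 120 nM within an estimated range from 50 nM to 300 nM on this read-out.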

Compound 4, half-maximal inhibitory concentration: 21.8 nM
The estimate for compound 4 lay 5.5-fold (0.74 log units) above the measured number; measured number below the stated range.
By their numbers in this assay, from the lowest: compound 4; then compounds 2 and 3 (each within the scatter of the next); then compound 1.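

In this assay, within the data shown here, the aryl group on this amino nitrogen proves more sensitive than the earlier compounds suggested: compound 2 and compound 3 stand level within the scatter, yet 4-cyanophenyl gives a 6.0-fold lower number from compound 3 to compound 4 (0.78 log units; beyond the scatter) and a 4.2-fold lower number from compound 2 to compound 4 (0.62 log units; beyond the scatter), clearing both. Against 3-methoxyphenyl the change gives an 18-fold lower number from compound 1 to compound 4 (1.26 log units; beyond the scatter), the only large step among these compounds, so the span available at this position is wider than the three earlier compounds showed. Among these compounds, the change also differs in kind from the earlier ones, since both the substituent and its number in the group's name change at once, whereas the earlier steps only exchanged one substituent for another under the same number. No supporting data bear on why this step occurs.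

Still open, going by these compounds, is whether the nitrile itself or its place on the ring carries the step, a question that 3-cyanophenyl and 4-chlorophenyl would separate. Also open, on these data alone, is how this position reads with other groups in the same place, such as 4-aminophenyl or 4-carboxyphenyl, and whether the step holds in any other assay.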